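The source may report more compounds than this note shows. Statements on the series, on what has been measured and on what is new or still open speak of the compounds shown alone.

Measured in a functional assay on LM7 cells (Homo sapiens) for cytotoxicity, read by MTT assay, with a stated time of 72 h; on this read-out higher numbers stand for weaker inhibition and lower numbers for stronger inhibition:
Compound 1 `Cc1nnc(SCc2cc(=O)c3ccccc3o2)o1` — compound 1 gives > 25000 nM.
Compound 2 `Cc1nnc(SCc2cc(=O)c3cc(Cl)ccc3o2)s1` — compound 2 gives > 25000 nM.

The value of compound 1 is a limit of the assay, not a number. The value of compound 2 is likewise only a limit. Compound 2 therefore sits at the limit of > 25000 nM in this assay, at which 2 of the 2 values shown sit, with nothing finer known about it.

Compound 3 `Cc1nnc(SCc2cc(=O)c3ccccc3o2)s1` differs from compound 2 by hydrogen in place of chloro on an aromatic carbon. Among the compounds with values here, no step between measured compounds is available, so the expected change in this assay is none beyond the usual scatter, the estimated step being a step that the limit leaves unreadable from compound 2 to compound 3. Compound 3 is expected to give 40000 nM, within 15000 nM to 120000 nM, most probably reported again only as a limit.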

Compound 3, half-maximal inhibitory concentration: > 25000 nM
Compound 3 ended at the assay's limit (the forecaster's own chance of this, stated with the estimate: 85%); the middle value lies beyond the limit too.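

No step can be read from compound 2 to compound 3 or from compound 1 to compound 3, each value being only a limit: the limit of > 25000 nM in this assay, at which 3 of the 3 values shown sit. The compounds shown leave open how strongly, if at all, any of the three inhibits these cells.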